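Aziridinylquinone series: carbamate chain in place of cyclohexyl

This account rests on a few compounds, and the source may have more. Where it says the series, first, only, none or still open, it means among the compounds named here.

Measured compounds:
compound 1 `CC1=C(N2CC2)C(=O)C(C2CCCCC2)=C(N2CC2)C1=O` 5.82
compound 2 `CCCC1=C(N2CC2)C(=O)C(C(COC(N)=O)OC)=C(N2CC2)C1=O` 5.63

Both were run in a functional assay on L1210 cells (Mus musculus), with a stated time of 12 days; a higher number here means a more potent compound, by a factor of ten per unit of this negative logarithm, a lower number a less potent compound. Compound 1 carries the upper of the two numbers, but the gap to compound 2 lies within the scatter, so neither can be called more potent. Compound 3 `CC1=C(N2CC2)C(=O)C(CCCOC(N)=O)=C(N2CC2)C1=O` is not yet measured. It differs from compound 1 by a group of 7 heavy atoms (4 carbon, 1 nitrogen, 2 oxygen; no ring) in place of a group of 6 heavy atoms (6 carbon; one six-membered non-aromatic ring of carbon only), on a double-bonded ring carbon: no ring, one hydrogen-bond donor and two acceptors enter on a double-bonded ring carbon of the shared core. For the measured compounds named here, no measured pair isolates this change. With compound 2 showing 5.63 for a related carbamate-bearing chain, the expected step of a number 0.12 log units lower from compound 1 to compound 3 (within the scatter) is small, within the scatter. Compound 3 is estimated at 5.7, between 5.2 and 6.3.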

Compound 3, logarithm of the reciprocal of the active concentration, log(1/C): 6.18
The estimate for compound 3 lay 0.48 log units below the measured number; measured number inside the range.
By their numbers in this assay, from the lowest: compounds 2 and 1 (each within the scatter of the next); then compound 3.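

On the double-bonded ring carbon, the open carbamate-bearing chain in place of cyclohexyl gives a number 0.36 log units higher from compound 1 to compound 3 (beyond the scatter) in this assay. For the compounds shown here, this is the first step beyond the scatter, and it shows that this position keeps potency without the carbon ring and with a hydrogen-bond donor and acceptors present. No available measurement bears on the reason for this step.

Still open, as far as these compounds go, is whether the carbamate or the open chain carries the step. The same chain ending in a hydroxyl group or an amine, on the shared core, would separate the two.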